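Swapping the aryl cap on a shared diol core

The compounds below may be only part of what the source reports. "The series", "measured", "known", "first", "only" and "open" are said of these compounds alone.

Compound 1 `CC1(C)CCC[C@]2(C)[C@@H](CC[C@@](C)(O)/C=C/c3cccc([N+](=O)[O-])c3)[C@](C)(O)CC[C@@H]12` gives 3380 nM in a functional assay on HeLa cells (Homo sapiens) for cytotoxicity, read by MTT assay, with a stated time of 48 h (on this read-out lower numbers stand for stronger inhibition and higher numbers for weaker inhibition), level with compound 2 `Cc1ccc(C)c(/C=C/[C@](C)(O)CC[C@@H]2[C@@]3(C)CCCC(C)(C)[C@@H]3CC[C@@]2(C)O)c1` at 3380 nM and together the lowest of the three numbers, while compound 3 `CC1(C)CCC[C@]2(C)[C@@H](CC[C@@](C)(O)/C=C/c3cncc4ccccc34)[C@](C)(O)CC[C@@H]12` sits far higher at 46000 nM. Compound 4 `CC1(C)CCC[C@]2(C)[C@@H](CC[C@@](C)(O)/C=C/c3ccc(Cl)nc3)[C@](C)(O)CC[C@@H]12` differs from compound 1 by 6-chloropyridin-3-yl in place of 3-nitrophenyl on a double-bonded chain carbon bound to a double-bonded chain carbon. Among the measured compounds shown here, two steps bear on this change: no change at the digits printed from compound 1 to compound 2 (within the scatter) shows that one single six-membered ring can replace another without effect, whereas a 14-fold higher number from compound 1 to compound 3 (1.13 log units; beyond the scatter) shows that a fused two-ring group costs a great deal. Since compound 4 keeps a single six-membered ring, an estimate close to compound 1 is expected, with a 1.2-fold higher number from compound 1 to compound 4 (0.07 log units; within the scatter) as the expected step. Compound 4 is therefore estimated at 4000 nM, with a range from 1500 nM to 12000 nM.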

Compound 4, half-maximal inhibitory concentration: 3680 nM
For compound 4 the middle estimate is 1.1-fold (0.04 log units) above the measured one, within the range that was stated.
By their numbers in this assay, from the lowest: compounds 1, 2 and 4 (each within the scatter of the next); then compound 3.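

Compound 4 puts a ring with a hetero atom and a chlorine at this place, where the earlier single rings held carbon only, and the number does not move beyond the scatter: a 1.1-fold higher number from compound 1 to compound 4 (0.04 log units; within the scatter) and a 1.1-fold higher number from compound 2 to compound 4 (0.04 log units; within the scatter). Isoquinolin-4-yl also has a ring hetero atom, yet the gap remains large: a 13-fold lower number from compound 3 to compound 4 (1.10 log units; beyond the scatter). A ring hetero atom alone therefore does not separate compound 3 from the other compounds.

Going by these compounds, whether a saturated cyclohexyl ring or an amine on the ring would hold the same level remains open. The data offer no explanation for the gap between the fused two-ring group and the single rings.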